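The source may report more compounds than this note shows. Statements on the series, on what has been measured and on what is new or still open speak of the compounds shown alone.

Measured compounds:
compound 1, `CCCN1CCN(c2ccccc2[N+](=O)[O-])CC1`, 7.94
compound 2, `CCCN1CCN(c2cccc([N+](=O)[O-])c2)CC1`, 7.7
compound 3, `CCCN1CCN(c2ccccc2C#N)CC1`, 7.92

The series is followed in a physicochemical assay for acid dissociation, using potentiometric titration. Compound 1 and compound 2 are built from the same atoms joined differently; the difference between the two cores is not broken down here. Their numbers in this assay, 7.94 for compound 1 and 7.7 for compound 2, fall within the scatter of one another, and compound 3 at 7.92 sits within the scatter of both as well.

One structural change is seen twice. From compound 1 to compound 3 it is cyano in place of nitro on an aromatic carbon, and the step it made was a number 0.02 log units lower from compound 1 to compound 3 (within the scatter). From compound 2 to the not yet measured compound 4, `CCCN1CCN(c2cccc(C#N)c2)CC1`, it is cyano in place of nitro on an aromatic carbon. The two are the same kind of change, not the same: in compound 1 the exchanged group stands ortho to a group of 9 heavy atoms, in compound 2 it stands meta to a group of 9 heavy atoms.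

For compound 4 the step from compound 2 is expected to be a number 0.02 log units lower from compound 2 to compound 4 (within the scatter), resting on the step from compound 1 to compound 3 of a number 0.02 log units lower from compound 1 to compound 3 (within the scatter). The surroundings of the place differ; the range is kept wide. Compound 4 is therefore estimated at 7.68, between 7.35 and 8.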

Compound 4, acid dissociation constant: 7.67
Compound 4: middle estimate off by 0.01 log units, on the high side; the measured number falls inside the stated range.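

In this assay the new step is a number 0.03 log units lower from compound 2 to compound 4 (within the scatter), and the earlier step is a number 0.02 log units lower from compound 1 to compound 3 (within the scatter); cyano in place of nitro on an aromatic carbon therefore stays within the scatter on both cores, including the one where it stands meta to a group of 9 heavy atoms. This shows that, for these two matched pairs, a step read on one core served as a usable guide on the other, but the two steps are too small to give the exchange a direction, and two pairs do not establish a rule for other cores or other read-outs. No measurement at hand explains why the two steps look alike, or why the exchange of nitro for cyano leaves the number within the scatter.

The compounds shown carry only nitro or cyano on the aromatic ring and only a propyl chain on the ring nitrogen, so it stays open whether trifluoromethyl, an amine or a carboxylic acid on that ring, or a longer chain in place of propyl, would stay within the scatter of these numbers. Also open, as far as these compounds go, is whether the exchange of nitro for cyano would behave the same way on a core that differs more widely from these.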